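Lengthening the chain from compound 3 to compound 4

This account rests on a few compounds, and the source may have more. Where it says the series, first, only, none or still open, it means among the compounds named here.

Compound 1 `CCCCCCc1ccc(-c2c(C)[nH]c(=O)n2C)cc1` – 9000 nM
Compound 2 `CCCCCCCc1ccc(-c2c(C)[nH]c(=O)n2C)cc1` – 8400 nM
Compound 3 `CCCCCCCCc1ccc(-c2c(C)[nH]c(=O)n2C)cc1` – 19400 nM

In a functional assay on brain (Rattus norvegicus, strain Wistar) for inhibition (on this read-out lower numbers stand for stronger inhibition and higher numbers for weaker inhibition), compound 3 (19400 nM) has the highest number of the three and is the weakest inhibitor measured so far. The remaining two values lie within the scatter of each other, as a 1.1-fold lower number from compound 1 to compound 2 (0.03 log units; within the scatter) shows.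

The unmeasured compound 4 `CCCCCCCCCCCCc1ccc(-c2c(C)[nH]c(=O)n2C)cc1` differs from compound 3 on the chain alone, the shared core staying the same. The change is butyl in place of hydrogen on a saturated chain carbon, eight bonds along the chain from an aromatic carbon and it extends the chain further than any measured step does.

Going by the values given here, three measured steps bear on it, and all of them lengthen the chain. The first, a 1.1-fold lower number from compound 1 to compound 2 (0.03 log units; within the scatter), moved nothing beyond the scatter. The other two, a 2.3-fold higher number from compound 2 to compound 3 (0.36 log units; beyond the scatter) and a 2.2-fold higher number from compound 1 to compound 3 (0.33 log units; beyond the scatter), were modest and both pointed towards weaker inhibition. Three compounds make only a thin basis, and nothing measured covers a chain this long. A modest step towards a higher number therefore seems the likeliest outcome, with wide uncertainty.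

The estimate amounts to a 2.0-fold higher number from compound 3 to compound 4 (0.29 log units; within the scatter) as the expected step in this assay for this change.

Compound 4 is estimated at 38000 nM with an expected range from 13000 nM to 110000 nM in this read-out.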

Compound 4, half-maximal inhibitory concentration: 13000 nM
For compound 4 the middle estimate is 2.9-fold (0.47 log units) above the measured one; the range from low to high includes it.
By their numbers in this assay, from the lowest: compounds 2, 1, 4 and 3 (each within the scatter of the next, the first and the last beyond it).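

In this assay butyl in place of hydrogen on a saturated chain carbon, eight bonds along the chain from an aromatic carbon, gives a step within the scatter (a 1.5-fold lower number from compound 3 to compound 4 (0.17 log units; within the scatter)), so the move towards weaker inhibition seen on reaching compound 3 (a 2.3-fold higher number from compound 2 to compound 3 (0.36 log units; beyond the scatter)) does not carry on to this longer chain. Compound 4 also cannot be told apart from the two shorter-chain compounds, since both of these steps lie within the scatter as well (a 1.5-fold higher number from compound 2 to compound 4 (0.19 log units; within the scatter); a 1.4-fold higher number from compound 1 to compound 4 (0.16 log units; within the scatter)), which means that lengthening the chain does not steadily weaken inhibition across these four compounds, and compound 3 is the one that goes against a flat picture. Nothing in the information available accounts for this behaviour of the chain.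

From the compounds shown here alone, what a chain longer than that of compound 4 would do remains open, and so does the behaviour of chain lengths falling between those of compound 3 and compound 4. Going by these compounds, it is also open how a chain ending in an amine or a carboxylic acid would compare with these plain carbon chains on the shared core.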